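A few compounds are considered here, and "the series" means these few. Any claim that something is new, unique, unknown or untested is made for them only; others in the source may bear on it.

Measured compounds in an assay on HEK293 cells for negative allosteric modulation of metabotropic glutamate receptor 5 (Homo sapiens), read by FLIPR, with a stated time of 1 h; on this read-out lower numbers stand for stronger inhibition and higher numbers for weaker inhibition:
Compound 1, `O=C1NCCc2nc(C#Cc3ccccc3F)sc21`, gives only the assay limit > 10000 nM.
Compound 2, `COc1ccccc1C#Cc1nc2c(s1)C(=O)NCC2`, likewise gives only the assay limit > 10000 nM.
Compound 3, `O=C(C1CC1)N1CCc2nc(C#Cc3ccccc3)sc2C1`, gives 290 nM.

For the measured compounds named here, compound 3 thus holds the only numerical value in the set; the other two results are limits, as the limit of > 10000 nM in this assay, at which 2 of the 3 values shown sit, records. Going by the values given here, the one step between measured compounds, a step that the two limits leave unreadable from compound 1 to compound 2, runs from one limit to another and cannot be sized; it also concerns the aromatic end of the molecule and not the amide.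

Compound 4, `O=C(C1CCCC1)N1CCc2nc(C#Cc3ccccc3)sc2C1`, differs from compound 3 at the carbonyl carbon: cyclopentyl in place of cyclopropyl on a carbonyl carbon. Among the compounds with values here, no measured step touches this part of the series, so there is nothing to read the effect of enlarging the ring on the carbonyl carbon from; the step from compound 1 to compound 2 offers no guide here.

The expectation is therefore a step of a 1.0-fold higher number from compound 3 to compound 4 (0.01 log units; within the scatter), no larger than the usual scatter, in no settled direction. For compound 4 the estimated value in this assay is 300 nM, with the range 100 nM to 1000 nM.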

Compound 4, half-maximal inhibitory concentration: > 10000 nM
Compound 4 ended at the assay's limit (the forecaster's own chance of this, stated with the estimate: 10%); middle value at least 33-fold (1.52 log units) away from the limit.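

The position on a carbonyl carbon whose other neighbours are an amide-type nitrogen in a ring is now shown to matter: in this assay, cyclopentyl in place of cyclopropyl gives an at least 34-fold higher number from compound 3 to compound 4 (1.53 log units; beyond the scatter). For the compounds shown here, this is the first step that can be sized, since the only earlier step ran between two limits at the aromatic end and could not be read, and it shows that a change confined to the cycloalkyl group, from 3 heavy atoms to 5, is enough to take a measurable compound out of the measurable range. The result for compound 4 is a limit and not a number, so the true size of the step stays open on its upper side: the limit of > 10000 nM in this assay, at which 3 of the 4 values shown sit.

The compounds shown leave open whether the loss follows ring size in a graded way, since cyclobutyl, which would fall between cyclopropyl and cyclopentyl, does not appear among them, and neither do open-chain groups such as isopropyl or methoxymethyl on the same carbonyl carbon. They also leave open whether a fluoro or methoxy on the phenyl ring would shift the value of the cyclopropylcarbonyl amide of compound 3.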